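Swapping the Pyridine Attachment in Cytotoxic Dienone Analogues

The source may hold more compounds than are shown below. What is called first, only, known or untested is meant among the compounds shown, and "the series" means these compounds.

Compound 1 `COc1cc(/C=C2\CN(C)C/C(=C\c3cccnc3)C2=O)cc(OC)c1` and compound 3 `COc1cc(/C=C2\CN(C)C/C(=C\c3ccncc3)C2=O)cc(OC)c1` share one core and differ only by pyridin-4-yl in place of pyridin-3-yl on a double-bonded chain carbon bound to a double-bonded ring carbon. In a functional assay on QGY-7703 cells (Homo sapiens) for cytotoxicity, read by MTT assay, with a stated time of 24 h (a higher number here means a weaker inhibitor, a lower number a stronger inhibitor), compound 1 gives 7900 nM and compound 3 gives 8400 nM, a step of a 1.1-fold higher number from compound 1 to compound 3 (0.03 log units; within the scatter). Compound 2 `CN1C/C(=C\c2cccnc2)C(=O)/C(=C/c2ccccc2F)C1` has a different core; how the two cores differ is not broken down here. In this assay compound 2 gives 4470 nM, which lies within the scatter of the values of compound 1 and compound 3. Compound 4 `CN1C/C(=C\c2ccncc2)C(=O)/C(=C/c2ccccc2F)C1` has not been measured. It differs from compound 2 by pyridin-4-yl in place of pyridin-3-yl on a double-bonded chain carbon bound to a double-bonded ring carbon, the same change at the same place as between compound 1 and compound 3. Because that change gave only a 1.1-fold higher number from compound 1 to compound 3 (0.03 log units; within the scatter), the step from compound 2 to compound 4 is expected to be similarly small, a 1.1-fold higher number from compound 2 to compound 4 (0.04 log units; within the scatter). In this assay compound 4 is therefore estimated at 4900 nM, likely between 2500 nM and 9500 nM.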

Compound 4, half-maximal inhibitory concentration: 4900 nM
For compound 4 middle estimate and measured number coincide at the digits printed, within the range that was stated.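

On the second core, pyridin-4-yl in place of pyridin-3-yl gives a 1.1-fold higher number from compound 2 to compound 4 (0.04 log units; within the scatter) in this assay. Set beside the earlier step, the change carries from one core to the other with no difference that can be told apart: the same change on two cores in this assay, a 1.1-fold higher number (0.03 log units; within the scatter) from compound 1 to compound 3 and a 1.1-fold higher number (0.04 log units; within the scatter) from compound 2 to compound 4, 1.0-fold (0.01 log units) apart, within the scatter of two such steps. For the compounds shown here, this shows only that the swap stays small on these two cores in this one assay; with both steps within the scatter, it does not show that the swap has any effect of its own, or that it would stay as small on a further core.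

The compounds shown leave open how a pyridin-2-yl group would read at the same place. They also leave open whether an amine or a carboxylic acid on the pyridine ring would shift the number.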